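Ortho-Substituted Hydrazone Analogues Tested for Antiproliferative Activity

The source may report more compounds than this note shows. Statements on the series, on what has been measured and on what is new or still open speak of the compounds shown alone.

Compound 1 `CCCSc1nc(N/N=C/c2ccc(C)cc2)c2nnn(Cc3ccccc3)c2n1`: > 64000 nM in a functional assay on MGC-803 cells (Homo sapiens) for antiproliferative activity, read by MTT assay, with a stated time of 72 h; on this read-out lower numbers stand for stronger inhibition and higher numbers for weaker inhibition (a limit of the assay)
Compound 2 `CCCSc1nc(N/N=C/c2ccccc2Cl)c2nnn(Cc3ccccc3)c2n1`: 10900 nM
Compound 3 `CCCSc1nc(N/N=C/c2ccc(Cl)cc2)c2nnn(Cc3ccccc3)c2n1`: > 64000 nM (a limit of the assay)

Going by the values given here, compound 2 is the only member of this set with a measured number in this assay; the other two values are limits. The step of an at least 5.8-fold lower number from compound 1 to compound 2 (0.76 log units; beyond the scatter) and the step of an at least 5.8-fold higher number from compound 2 to compound 3 (0.76 log units; beyond the scatter) both point the same way: the 2-chlorophenyl group of compound 2 gives a measurable number where the 4-methylphenyl group and the 4-chlorophenyl group do not, with both of the latter resting at the limit of > 64000 nM in this assay, at which 2 of the 3 values shown sit. Compound 4 `CCCSc1nc(N/N=C(\C)c2ccccc2O)c2nnn(Cc3ccccc3)c2n1` differs from compound 2 by a group of 10 heavy atoms (8 carbon, 1 nitrogen, 1 oxygen; one six-membered aromatic ring of carbon only) in place of a group of 9 heavy atoms (7 carbon, 1 nitrogen, 1 chlorine; one six-membered aromatic ring of carbon only), on a nitrogen on an aromatic ring. Among the compounds with values here, no measured step describes the hydroxyl or the added methyl on the carbon with a double bond to nitrogen, so the expectation rests only on the pattern that compound 2 set. Compound 4 is therefore estimated at 15000 nM, with a range of 3500 nM to 64000 nM, meaning an expected step of a 1.4-fold higher number from compound 2 to compound 4 (0.14 log units; within the scatter), which is within the scatter.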

Compound 4, half-maximal inhibitory concentration: 2310 nM
Compound 4: the middle estimate sits 6.5-fold (0.81 log units) above what was measured, and the stated range ends above it.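

In this assay, the change on a nitrogen on an aromatic ring shows that a measured number in this series is not confined to the 2-chlorophenyl group of compound 2, since the group carrying the hydroxyl and the added methyl gives a 4.7-fold lower number from compound 2 to compound 4 (0.67 log units; beyond the scatter). The distance to the other two compounds is larger, with an at least 27-fold lower number from compound 3 to compound 4 (1.44 log units; beyond the scatter) and an at least 27-fold lower number from compound 1 to compound 4 (1.44 log units; beyond the scatter), though each of these steps starts from a limit of the assay and not from a number. Compound 1 and compound 3 both remain at such a limit: the limit of > 64000 nM in this assay, at which 2 of the 4 values shown sit.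

Compound 4 differs from compound 2 in both the hydroxyl and the added methyl, so the compounds shown do not separate the share of each in the step. Also open, as far as these compounds go, is what an amine in place of the hydroxyl, or an ethyl group in place of the added methyl, would give in this assay.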